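A few compounds are considered here, and "the series" means these few. Any claim that something is new, unique, unknown or untested is made for them only; others in the source may bear on it.

Measured in an assay on HepG2 cells for activation of nuclear factor erythroid 2-related factor 2 (Homo sapiens), read by a luciferase reporter, with a stated time of 5 h; a higher number here means that more compound is needed for the effect, a lower number that less compound is needed:
compound 1 `COc1ccc(/C=C/c2ccc(F)cc2)cc1` — 4200 nM
compound 2 `COc1cccc(/C=C/c2cccc(F)c2)c1` — 2300 nM
compound 3 `COc1ccc(/C=C/c2ccc(F)cc2)cc1OC` — 2600 nM

All three numbers in this assay lie within the usual scatter of one another, so no order among compound 1, compound 2 and compound 3 is drawn. Going by the values given here, the step of a 1.6-fold lower number from compound 1 to compound 3 (0.21 log units; within the scatter) is the one measured instance of this change: methoxy in place of hydrogen on an aromatic carbon. Compound 4 `COc1cccc(/C=C/c2cccc(F)c2)c1OC` is not yet measured and carries the same kind of change on the core of compound 2: methoxy in place of hydrogen on an aromatic carbon. The place differs: in compound 3 the entering methoxy sits meta to a group of 9 heavy atoms, in compound 4 ortho to it. How the core of compound 2 differs from that of compound 1 is not broken down here. Resting on the step from compound 1 to compound 3, which was within the scatter, the expected step of a 1.3-fold lower number from compound 2 to compound 4 (0.11 log units; within the scatter) is small. Compound 4 is estimated at 1800 nM in this assay, expected between 800 nM and 4500 nM.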

Compound 4, half-maximal effective concentration: 1900 nM
For compound 4 the middle estimate is 1.1-fold (0.02 log units) below the measured one, within the range that was stated.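

With methoxy in place of hydrogen on an aromatic carbon, a 1.2-fold lower number from compound 2 to compound 4 (0.08 log units; within the scatter) is the second reading of this change in this assay and stays small. Set beside the earlier step, the change reads alike on the two cores: the same change on two cores in this assay, a 1.6-fold lower number (0.21 log units; within the scatter) from compound 1 to compound 3 and a 1.2-fold lower number (0.08 log units; within the scatter) from compound 2 to compound 4, 1.3-fold (0.13 log units) apart, within the scatter of two such steps

So, on these two cores, the change carries over without any difference beyond the scatter, but neither step shows that methoxy moves the number, and two small steps do not establish a rule for other cores or separate any influence of where the methoxy sits.

Still open, as far as these compounds go, is whether an amine, a carboxylic acid or a longer alkoxy chain in place of methoxy would give a step beyond the scatter. Whether such a step would carry from one core to the other is open as well.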